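The source may hold more compounds than are shown below. What is called first, only, known or untested is meant among the compounds shown, and "the series" means these compounds.

Measured compounds:
compound 1, `C[C@H](NC(=O)[C@@]1(Cc2ccccc2)CCN1C(=O)OCc1ccccc1)C(=O)N(C)C`, in an ADME assay on HELF cells (Homo sapiens) for cytotoxicity, with a stated time of 3 days (a lower number here means that less compound is tolerated, a higher number that more compound is tolerated), compound 1 gives > 100000 nM.
compound 2, `C[C@H](NC(=O)[C@]1(Cc2ccccc2)CCN1C(=O)OCc1ccccc1)C(=O)NC(C)(C)C`, in this assay compound 2 gives > 100000 nM.

Both of these values are limits of the assay rather than numbers. For compound 2 the reading of > 100000 nM in this assay is a limit, so compound 2 stands only at the edge of what the assay reports. The picture is summed up by the limit of > 100000 nM in this assay, at which 2 of the 2 values shown sit, with every shown value sitting on that limit.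

Compound 3, `C[C@H](NC(=O)[C@]1(Cc2ccccc2)CCN1C(=O)OCc1ccccc1)C(=O)N(C)C`, has yet to be measured in this assay. It differs from compound 2 in one place: dimethylamino in place of (tert-butyl)amino on a carbonyl carbon. Among the measured compounds shown here, no step between measured compounds is available to calibrate this change, so the expectation rests on where compound 2 sits and on the fact that compound 1, which also carries a dimethylamino group on that carbonyl carbon, sits at the same limit.

The step from compound 2 to compound 3 in this assay is expected to be none beyond the scatter, namely a step that the limit leaves unreadable from compound 2 to compound 3. Compound 3 is therefore estimated at 120000 nM, with a range from 50000 nM to 300000 nM, most likely reported again as a limit.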

Compound 3, minimum cytotoxic concentration: > 100000 nM
Compound 3: only a limit was reported; the forecaster's own chance of this, stated with the estimate: 85%; the middle value is on the limit's open side.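

In this assay compound 3 gives > 100000 nM, which is a limit of the assay. No step can be read from compound 2 to compound 3 or from compound 1 to compound 3: the limit of > 100000 nM in this assay, at which 3 of the 3 values shown sit. The compounds shown leave open whether swapping (tert-butyl)amino for dimethylamino, or changing the configuration as drawn, alters the minimum cytotoxic concentration at all.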